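Methylsulfonyl analogue of compound 2: expectation before measurement

The source may hold more compounds than are shown below. What is called first, only, known or untested is meant among the compounds shown, and "the series" means these compounds.

In an assay on isolated protein for inhibition of prostaglandin E2 receptor EP1 subtype (Homo sapiens) (on this read-out lower numbers stand for stronger inhibition and higher numbers for weaker inhibition), compound 1 `O=C(O)c1cccc(C2=C(c3cc(Br)ccc3OCc3ccc(F)cc3F)CCC2)c1` gives 5.01 nM, compound 2 `CSc1ccc(OCc2ccc(F)cc2F)c(C2=C(c3cccc(C(=O)O)c3)CCC2)c1` gives 15.9 nM and compound 3 `CSc1ccc(OCc2ccc(F)cc2)c(C2=C(c3cccc(C(=O)O)c3)CCC2)c1` gives 31.6 nM. Compound 2 thus stands second highest of the three numbers. The measured steps are a 3.2-fold higher number from compound 1 to compound 2 (0.50 log units; beyond the scatter) and a 2.0-fold higher number from compound 2 to compound 3 (0.30 log units; within the scatter). Compound 4 `CS(=O)(=O)c1ccc(OCc2ccc(F)cc2F)c(C2=C(c3cccc(C(=O)O)c3)CCC2)c1` differs from compound 2 by methylsulfonyl in place of methylsulfanyl on an aromatic carbon. Going by the values given here, no measured step exchanges methylsulfanyl for methylsulfonyl: the step from compound 1 to compound 2 is a different exchange, and the step from compound 2 to compound 3 is a change elsewhere. Neither gives a direction, so for compound 4 in this assay no step beyond the scatter is expected, namely a 1.6-fold higher number from compound 2 to compound 4 (0.20 log units; within the scatter). Compound 4 is estimated at 25 nM, between 8 nM and 80 nM.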

Compound 4, half-maximal inhibitory concentration: 15.9 nM
Compound 4: the middle estimate sits 1.6-fold (0.20 log units) above what was measured, and the stated range covers the measured number.
By their numbers in this assay, from the lowest: compound 1; then compounds 2, 4 and 3 (each within the scatter of the next).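

At the position para to a (2,4-difluorobenzyl)oxy group, this assay gives no change at the digits printed from compound 2 to compound 4 (within the scatter) on exchanging methylsulfanyl for methylsulfonyl, so the read-out does not separate these two sulfur groups here. Bromo remains the only group at this position with a lower number, with a 3.2-fold higher number from compound 1 to compound 4 (0.50 log units; beyond the scatter) and no gain from the sulfonyl form. No supporting data offer an explanation for this result. As far as these compounds go, whether an amine, a carboxylic acid or a longer chain at this position would give a similar number remains open.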